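Swapping a Pyridine Ring for Fluoro in a Cytotoxic Series

The source may report more compounds than this note shows. Statements on the series, on what has been measured and on what is new or still open speak of the compounds shown alone.

Compound 1 `N#Cc1ccc(NC(=O)c2ccc(Br)cc2O)c(Cl)c1` gives 730 nM
Compound 2 `N#Cc1ccc(NC(=O)c2ccc(-c3cccnc3)cc2O)cc1` gives 6660 nM
Compound 3 `O=C(Nc1ccc(Cl)cc1Cl)c1ccc2cccnc2c1O` gives 610 nM

All three values come from a functional assay on HL-60 cells (Homo sapiens) for cytotoxicity, read by luminescence and CellTiter-Glo, with a stated time of 3 days (a higher number here means a weaker inhibitor, a lower number a stronger inhibitor), and they place compound 2 at 6660 nM as the highest number of the three. Its gaps to compound 1 and compound 3 both lie beyond the usual scatter, so compound 2 is the weakest inhibitor of the set.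

Compound 4 `N#Cc1ccc(NC(=O)c2ccc(F)cc2O)cc1` differs from compound 2 by a single change, fluoro in place of pyridin-3-yl on an aromatic carbon with the rest unchanged. Going by the values given here, no measured pair shows this change alone, so any forecast is uncertain. Compound 1 at 730 nM and compound 3 at 610 nM both lack the pyridin-3-yl and have lower numbers, although they also differ from compound 2 elsewhere. A moderate move towards stronger inhibition therefore seems likely, and the estimated size is a 2.7-fold lower number from compound 2 to compound 4 (0.43 log units; beyond the scatter) in the direction of a lower number. In this assay compound 4 is expected at 2500 nM with an estimated range from 700 nM to 8000 nM until it is measured.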

Compound 4, half-maximal inhibitory concentration: 1380 nM
Compound 4: the middle estimate sits 1.8-fold (0.26 log units) above what was measured; the range from low to high includes it.
By their numbers in this assay, from the lowest: compounds 3, 1 and 4 (each within the scatter of the next, the first and the last beyond it); then compound 2.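

In this assay there is now a comparison that differs in one place only: fluoro in place of pyridin-3-yl gives a 4.8-fold lower number from compound 2 to compound 4 (0.68 log units; beyond the scatter), a modest step that lies beyond the scatter. At this aromatic carbon, meta to a hydroxy group and para to a large group, a six-membered aromatic ring is therefore not required for cytotoxicity, and a single fluorine atom gives the lower number of the two. Nothing measured here explains the step, so the reason for it remains unknown.

From the compounds shown here alone, it remains open whether a phenyl ring, with carbon only, would behave like pyridin-3-yl, and where an amine, a methoxy group or a carboxylic acid at this carbon would fall. A single pair also cannot show whether the same swap would give a similar step on a different core.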